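A few compounds are considered here, and "the series" means these few. Any claim that something is new, unique, unknown or untested is made for them only; others in the source may bear on it.

Measured so far:
compound 1 `CCc1nc2c(C)cc(C)nn2c1Cc1ccc(/C=C/CN2CCN(C(C)C)CC2)cc1` — 74 nM
compound 2 `CCc1nn2c(C)cc(C)nc2c1Cc1ccc(CCC(O)C2CCNCC2)cc1` — 24 nM

In a functional assay on HeLa cells for antagonist activity at G-prodeshotein coupled receptor 4 (Homo sapiens), read by HTRF and cAMP accumulation, with a stated time of 15 min (a higher number here means a weaker inhibitor, a lower number a stronger inhibitor), compound 2 gives 24 nM, the lowest of the two numbers. Compound 1 gives 74 nM; the gap to compound 2 lies beyond the scatter.

Compound 3 `CCc1nn2c(C)cc(C)nc2c1Cc1ccc(CCCC2(O)CCNCC2)cc1` differs from compound 2 by (4-hydroxypiperidin-4-yl)methyl in place of hydroxy(piperidin-4-yl)methyl on a saturated chain carbon, two bonds along the chain from an aromatic carbon. Within the data shown here, no measured pair covers a move of this kind, so the direction is uncertain. The step from compound 2 to compound 3 is expected to be small, a 1.7-fold higher number from compound 2 to compound 3 (0.22 log units; within the scatter), most likely within the scatter or a little toward a weaker inhibitor. Compound 3 is estimated at 40 nM, with a range from 12 nM to 130 nM.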

Compound 3, half-maximal inhibitory concentration: 50 nM
Estimate against measurement, compound 3: 1.3-fold (0.10 log units) below; low and high end bracket the measured number.
By their numbers in this assay, from the lowest: compound 2; then compounds 3 and 1 (each within the scatter of the next).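

In this assay, among these compounds, (4-hydroxypiperidin-4-yl)methyl in place of hydroxy(piperidin-4-yl)methyl gives a 2.1-fold higher number from compound 2 to compound 3 (0.32 log units; beyond the scatter), a modest step and the only one-place comparison so far. Rejoining the same atoms at this saturated chain position is thus enough to move the number, with the 3-hydroxy-3-(piperidin-4-yl)propyl arrangement holding the lower value. No measurement at hand bears on the reason for this step. Still open, going by these compounds, is whether the hydroxy group matters at all, as a methoxy group or an amine in its place would show. On these data alone, the effect of a longer chain also remains open.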